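Triazole hydrazone with a hydroxylated dibromophenyl end

The compounds below may be only part of what the source reports. "The series", "measured", "known", "first", "only" and "open" are said of these compounds alone.

Within the data shown here, in a functional assay on HCT-116 cells (Homo sapiens) for inhibition, read by MTT assay, with a stated time of 48 h (on this read-out higher numbers stand for weaker inhibition and lower numbers for stronger inhibition), compound 2 `O=C(CSc1nnc(-c2ccncc2)n1-c1ccccc1)N/N=C/c1ccc(Br)cc1` gives 4500 nM, the lowest of the two numbers known so far, while compound 1 `Brc1ccc(CSc2nnc(-c3ccncc3)n2-c2ccccc2)cc1` gives 11100 nM, a gap that lies beyond the usual scatter. Compound 3 `O=C(CSc1nnc(-c2ccncc2)n1-c1ccccc1)N/N=C/c1cc(Br)cc(Br)c1O` is not yet measured; it carries 3,5-dibromo-2-hydroxyphenyl in place of 4-bromophenyl on a carbon with a double bond to nitrogen, the rest of the structure being kept. Among the measured compounds shown here, no measured pair shows this change, so its size is unknown. The step is expected to be modest and toward stronger inhibition, a 1.5-fold lower number from compound 2 to compound 3 (0.18 log units; within the scatter), and might still fall within the scatter. For compound 3 the estimate in this assay is 3000 nM, within a range from 900 nM to 10000 nM.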

Compound 3, half-maximal inhibitory concentration: 4500 nM
Estimate against measurement, compound 3: 1.5-fold (0.18 log units) below; measured number inside the range.
By their numbers in this assay, from the lowest: compounds 2 and 3 (each within the scatter of the next); then compound 1.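

The reading of no change at the digits printed from compound 2 to compound 3 (within the scatter) in this assay shows that this position, on a carbon with a double bond to nitrogen, takes the larger 3,5-dibromo-2-hydroxyphenyl as well as it takes 4-bromophenyl. This single step cannot separate the contribution of the added bromine from that of the hydroxyl, which may each matter or not at all. No supporting data bear on why the number stays flat. As far as these compounds go, whether a phenyl carrying only the hydroxyl would read the same remains open, as does the effect of an amine or a carboxylic acid at this place.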